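Trading a fluorine for two chlorines on the benzyl arm

The compounds below may be only part of what the source reports. "The series", "measured", "known", "first", "only" and "open" are said of these compounds alone.

Three compounds have been measured in an assay on CHO cells for binding affinity to corticotropin-releasing factor receptor 1 (Homo sapiens); a higher number here means a weaker inhibitor, a lower number a stronger inhibitor:

Compound 1 `CCCCN(CC)c1cc(C)nc2c(-c3cnc(N(C)C)cc3C)c(C)nn12`: 2.6 nM
Compound 2 `CCN(Cc1ccc(C)cc1)c1cc(C)nc2c(-c3cnc(N(C)C)cc3C)c(C)nn12`: 2.3 nM
Compound 3 `CCN(Cc1ccccc1F)c1cc(C)nc2c(-c3cnc(N(C)C)cc3C)c(C)nn12`: 3.4 nM

Compound 3 has the highest number of the three, but its gaps to the others, a 1.3-fold higher number from compound 1 to compound 3 (0.12 log units; within the scatter) and a 1.5-fold higher number from compound 2 to compound 3 (0.17 log units; within the scatter), both lie within the scatter, so the three cannot be told apart. Compound 4 `CCN(Cc1ccc(Cl)c(Cl)c1)c1cc(C)nc2c(-c3cnc(N(C)C)cc3C)c(C)nn12` differs from compound 3 by 3,4-dichlorophenyl in place of 2-fluorophenyl on a saturated chain carbon bound to a nitrogen on an aromatic ring. Among the measured compounds shown here, the steps that bear on this are the earlier swaps at the same place: a 1.1-fold lower number from compound 1 to compound 2 (0.05 log units; within the scatter), a 1.3-fold higher number from compound 1 to compound 3 (0.12 log units; within the scatter) and a 1.5-fold higher number from compound 2 to compound 3 (0.17 log units; within the scatter), none of them beyond the scatter. Changing the group on this carbon has so far left this assay essentially untouched, and no step beyond the scatter is expected here either. Compound 4 is estimated at 3 nM, with a range from 1.2 nM to 8 nM, which means an expected step of a 1.1-fold lower number from compound 3 to compound 4 (0.05 log units; within the scatter).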

Compound 4, inhibition constant: 2.5 nM
The estimate for compound 4 lay 1.2-fold (0.08 log units) above the measured number; measured number inside the range.
By their numbers in this assay, from the lowest: compounds 2, 4, 1 and 3 (each within the scatter of the next).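

On a saturated chain carbon bound to a nitrogen on an aromatic ring, a phenyl carrying two chlorines can't be told apart in this assay from propyl, 4-methylphenyl or 2-fluorophenyl: the steps read (a 1.4-fold lower number from compound 3 to compound 4 (0.13 log units; within the scatter)), (a 1.1-fold higher number from compound 2 to compound 4 (0.04 log units; within the scatter)) and (a 1.0-fold lower number from compound 1 to compound 4 (0.02 log units; within the scatter)). So the tolerance seen so far now extends to a ring with two halogens instead of one. No measurement here accounts for this tolerance. From the compounds shown here alone, whether a benzyl arm bearing an amine or a carboxylic acid would also leave the number in this assay unchanged remains open.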